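Methoxy beside the phenol: compound 4 on the shared core

The source may hold more compounds than are shown below. What is called first, only, known or untested is meant among the compounds shown, and "the series" means these compounds.

Compound 1, `CCOC(=O)C1=C(C)NC(=S)NC1c1ccc(O)cc1`: in a functional assay on NCI-H460 cells (Homo sapiens) for inhibition, read by sulforhodamine B assay, with a stated time of 48 h (a higher number here means a weaker inhibitor of growth, a lower number a stronger inhibitor of growth), compound 1 reaches only the assay limit, > 250 ug/mL.
Compound 2, `CCOC(=O)C1=C(C)NC(=S)NC1c1ccc(F)cc1`: in this assay compound 2 gives 14.2 ug/mL.
Compound 3, `CCOC(=O)C1=C(C)NC(=S)NC1c1ccc(SC)cc1`: in this assay compound 3 gives 21.6 ug/mL.

Compound 1 stands at the limit of this assay; its value is a limit and not a number, (the limit of > 250 ug/mL in this assay, at which 1 of the 3 values shown sits). The two measured steps away from it are large: an at least 17-fold lower number from compound 1 to compound 2 (1.24 log units; beyond the scatter) and an at least 11-fold lower number from compound 1 to compound 3 (1.06 log units; beyond the scatter). Between the fluoro and methylsulfanyl compounds the step is small, a 1.5-fold higher number from compound 2 to compound 3 (0.18 log units; within the scatter).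

Compound 4, `CCOC(=O)C1=C(C)NC(=S)NC1c1ccc(O)c(OC)c1`, keeps the hydroxy group of compound 1 and adds one group: methoxy in place of hydrogen on an aromatic carbon. Among the compounds with values here, neither measured step keeps the hydroxy group, so none bears directly on this change; both show only that compound 1 lies far above the two numbered compounds. Compound 4 is therefore expected to stay near compound 1, with a step of an at least 1.3-fold lower number from compound 1 to compound 4 (0.14 log units; that floor lies within the scatter), and to land at about 180 ug/mL, within 50 ug/mL to 250 ug/mL.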

Compound 4, concentration for 50% growth inhibition: 180 ug/mL
Beside the measured number, compound 4's estimate shows no gap at the digits printed, within the range that was stated.
By their numbers in this assay, from the lowest: compounds 2 and 3 (each within the scatter of the next); then compound 4. At a limit, above all of these: compound 1.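

Methoxy on an aromatic carbon, ortho to a hydroxy group, gives a compound that keeps the hydroxy group a measured number rather than a limit: in this assay compound 4 gives 180 ug/mL. The step is an at least 1.3-fold lower number from compound 1 to compound 4 (0.14 log units; that floor lies within the scatter), so the data fix only a floor for this change and cannot say how large its true effect is. Compound 1 remains a limit and not a number: the limit of > 250 ug/mL in this assay, at which 1 of the 4 values shown sits.

The compounds shown leave open whether a different group at this place, such as ethoxy, an amine or a carboxylic acid, would give a lower number than methoxy does. They also leave open what methoxy at a comparable place would do on a compound without the hydroxy group, such as compound 2 with its fluoro group.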